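Adding a Methyl Where the Read-Out Is Already High

A few compounds are considered here, and "the series" means these few. Any claim that something is new, unique, unknown or untested is made for them only; others in the source may bear on it.

Compound 1 `Cc1ccc(-c2csc(N/N=C/c3cccs3)n2)cc1` and compound 2 `Clc1ccc(/C=N/Nc2nc(-c3ccccc3)cs2)c(Cl)c1` share one core and were both run in a functional assay, read by spectrophotometry, with a stated time of 15 min, tested at 100 ug/mL; on this read-out lower numbers stand for a weaker effect and higher numbers for a stronger effect at the one concentration tested. In this assay compound 1 gives 98.1%, and in this assay compound 2 gives 95.8%. Compound 2 holds the lowest of the two numbers, yet its gap to compound 1 lies within the scatter, so the two read as alike. Compound 3 `Cc1ccc(-c2csc(N/N=C/c3ccc(Cl)cc3Cl)n2)cc1` is compound 2 with a single change: methyl in place of hydrogen on an aromatic carbon. Going by the values given here, no pair of measured compounds shows what this change does here. Because compound 2 gives 95.8% close to the top of the scale, little room remains for a rise, and nothing points to a fall beyond the scatter. The step from compound 2 to compound 3 is therefore expected to be a number 0.2 percentage points higher from compound 2 to compound 3 (within the scatter), essentially none beyond the scatter. Compound 3 is estimated to give 96%, within a range of 88% to 100%.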

Compound 3, a percentage reported as inhibition, at one concentration (the size of the read-out at that concentration, not a potency): 95.1%
The estimate for compound 3 lay 0.9 percentage points above the measured number; the range from low to high includes it.
By their numbers in this assay, from the lowest: compounds 3, 2 and 1 (each within the scatter of the next).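

The change from phenyl to 4-methylphenyl now has a measured step: adding methyl on an aromatic carbon, para to a large group, gives a number 0.7 percentage points lower from compound 2 to compound 3 (within the scatter) in this assay and so leaves no change that can be told from the scatter. This position therefore accepts the methyl with the read-out still high, although compound 2 and compound 3 both sit near the top of the scale at the one concentration tested, where a real difference in potency could stay hidden. Nothing measured here explains this result. From the compounds shown here alone, whether an amine, a carboxylic acid or a longer chain at this position would keep the read-out as high remains open. Also open, going by these compounds, is whether the methyl would still give so small a step at a lower concentration.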